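The source may hold more compounds than are shown below. What is called first, only, known or untested is meant among the compounds shown, and "the series" means these compounds.

Of the compounds shown here, two sharing one core have numbers so far: compound 1 `CCc1cccc2c(OC)c(-c3occ(C)c3C(=O)OC)ccc12` and compound 2 `CCOc1c(-c2occ(C)c2C(=O)OC)ccc2c(CC)cccc12`. In a functional assay on SK-BR-3 cells (Homo sapiens) for cytotoxicity, read by MTT assay, with a stated time of 72 h (on this read-out higher numbers stand for an effect only at larger amounts of compound and lower numbers for an effect already at smaller amounts), compound 1 gives 1.2 ug/mL and compound 2 gives 1.9 ug/mL. Among the compounds with values here, the only measured step, a 1.6-fold higher number from compound 1 to compound 2 (0.20 log units; within the scatter), is methyl in place of hydrogen on a saturated chain carbon bound to an oxygen on an aromatic ring, so compound 2 stands within the scatter of its single neighbour. The next structure is compound 3 `CCOc1c(-c2occ(C)c2CO)ccc2c(CC)cccc12`, which differs from compound 2 by hydroxymethyl in place of methoxycarbonyl on an aromatic carbon. Within the data shown here, the measured step sits on another part of the molecule, and no measured pair tests this new change. That step therefore gives only a weak guide, and the two values offer little more than a starting point. The expected step in this assay is a 1.6-fold higher number from compound 2 to compound 3 (0.20 log units; within the scatter), an estimate that stays within the scatter and carries much uncertainty. For compound 3 the estimated value is 3 ug/mL, with an expected range from 0.8 ug/mL to 10 ug/mL.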

Compound 3, concentration for half-maximal effect: 8.8 ug/mL
Compound 3: the middle estimate sits 2.9-fold (0.47 log units) below what was measured; the measured number falls inside the stated range.
By their numbers in this assay, from the lowest: compounds 1 and 2 (each within the scatter of the next); then compound 3.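

In this assay the earlier step, a 1.6-fold higher number from compound 1 to compound 2 (0.20 log units; within the scatter), changed only the chain on the oxygen and gave no shift that could be told apart from ordinary scatter. Within the data shown here, the change on the five-membered aromatic ring with 1 oxygen gives a 4.6-fold higher number from compound 2 to compound 3 (0.67 log units; beyond the scatter), so this is the first place where a single replacement moves the number beyond the scatter, though the step is modest and it is only one pair. Here methoxycarbonyl, with 4 heavy atoms and 0 hydrogen-bond donors, leaves and hydroxymethyl, with 2 heavy atoms and 1 hydrogen-bond donor, enters, and more of the compound is then needed for the same effect on these cells, while no measurement at hand accounts for this shift.

A single replacement cannot separate what losing methoxycarbonyl does from what gaining hydroxymethyl does. A carboxylic acid, an amide or a plain methyl on the same ring carbon would show whether the number follows the size of the group or something particular to the ester or the alcohol.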